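This account rests on a few compounds, and the source may have more. Where it says the series, first, only, none or still open, it means among the compounds named here.

Compound 2 `N#Cc1ccccc1C1N[C@H](C(=O)O)CS1` reaches in a physicochemical assay, with a stated time of 50 min (a higher number here means a weaker inhibitor, a lower number a stronger inhibitor), only a limit, > 1000000 nM, not a number. Compound 1 `O=C(O)[C@@H]1CSC(c2cccc(F)c2F)N1` likewise gives in this assay only a limit, > 1000000 nM. Both readings fall at the limit of > 1000000 nM in this assay, at which 2 of the 2 values shown sit. Compound 3 `O=C(O)[C@@H]1CSC(c2ccccc2Br)N1` differs from compound 2 by bromo in place of cyano on an aromatic carbon. Among the compounds with values here, no measured step bounds this change, and with both known values at the limit no step beyond the scatter is expected in either direction. Compound 3 is therefore estimated near 1000000 nM, between 300000 nM and 3000000 nM, most likely again as a limit. That estimate means a step of a number no higher from compound 2 to compound 3 (the limit leaves the size open).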

Compound 3, half-maximal inhibitory concentration: 39100 nM
Compound 3: the middle estimate sits 26-fold (1.41 log units) above what was measured, outside the stated range (below it).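

Bromo in place of cyano on an aromatic carbon gives an at least 25-fold lower number from compound 2 to compound 3 (1.40 log units; beyond the scatter) in this assay, so a single change at this place can bring a reading off the limit. Compound 3 is the only one of the three compounds with a number rather than a limit, and the other two stay there: the limit of > 1000000 nM in this assay, at which 2 of the 3 values shown sit.

As far as these compounds go, what chloro, methyl or methoxy would give at this place stays open. From the compounds shown here alone, the full size of the step also stays open, with compound 2 known only as a limit.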